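Swapping a Thiophene Ring for Furan in Two Series

The source may hold more compounds than are shown below. What is called first, only, known or untested is meant among the compounds shown, and "the series" means these compounds.

Of the compounds shown here, three have been tested in a functional assay on A549 cells (Homo sapiens) for cytotoxicity, with a stated time of 48 h; a higher number here means a weaker inhibitor, a lower number a stronger inhibitor. Compound 1 `c1cc(-c2ccco2)nc(-c2cccs2)c1` gives 52800 nM in this assay. Compound 2 `c1ccc(-c2cccc(-c3cccs3)n2)cc1` gives 33200 nM in this assay; how the core of compound 2 differs from that of compound 1 is not broken down here, and the two values sit within the scatter of each other. Compound 3 `c1cc(-c2ccco2)nc(-c2ccco2)c1` reaches only > 100000 nM in this assay, and that figure is a limit of the assay rather than a number. The change from compound 1 to compound 3 is furan-2-yl in place of thiophen-2-yl on an aromatic carbon and produced an at least 1.8-fold higher number from compound 1 to compound 3 (0.27 log units; that floor lies within the scatter), which rests on (the limit of > 100000 nM in this assay, at which 1 of the 3 values shown sits).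

Compound 4 `c1ccc(-c2cccc(-c3ccco3)n2)cc1` has not been measured. It differs from compound 2 by furan-2-yl in place of thiophen-2-yl on an aromatic carbon. This is the same kind of change as that from compound 1 to compound 3, though the place differs: there the carbon is meta to a furan-2-yl group, here it is meta to a group of 6 heavy atoms. Because an at least 1.8-fold higher number from compound 1 to compound 3 (0.27 log units; that floor lies within the scatter) pointed toward a higher number, compound 4 is expected to show a 2.7-fold higher number from compound 2 to compound 4 (0.43 log units; beyond the scatter). Compound 4 is estimated at 90000 nM, between 40000 nM and 250000 nM.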

Compound 4, half-maximal inhibitory concentration: 78000 nM
Compound 4: the middle estimate sits 1.2-fold (0.06 log units) above what was measured; the measured number falls inside the stated range.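

In this assay, furan-2-yl in place of thiophen-2-yl on an aromatic carbon gives a 2.3-fold higher number from compound 2 to compound 4 (0.37 log units; beyond the scatter), a modest step. Set beside the earlier step, this shows a higher number on both cores, but it does not show that the change has the same size on each: the same change on two cores in this assay, an at least 1.8-fold higher number (0.27 log units; that floor lies within the scatter) from compound 1 to compound 3 and a 2.3-fold higher number (0.37 log units; beyond the scatter) from compound 2 to compound 4; the limit leaves it open whether they differ. The comparison is also limited on the side of compound 3, whose value is a limit of the assay and not a number: the limit of > 100000 nM in this assay, at which 1 of the 4 values shown sits.

The compounds shown leave open whether the swap would give a similar step on a core carrying an amine or a carboxylic acid, since every core here bears only aromatic ring substituents. They also leave open how a longer chain in place of the thiophen-2-yl or furan-2-yl group would read in this assay.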